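The source may hold more compounds than are shown below. What is called first, only, known or untested is meant among the compounds shown, and "the series" means these compounds.

Measured so far:

Compound 1 `CC(C)(N)CC(=O)N[C@@H]1CCc2ccccc2N(Cc2ccc(-c3ccccc3S(=O)(=O)NC(C)(C)C)cc2)C1=O` — in a functional assay (Pituitary gland cell) with Rattus norvegicus as the target (a higher number here means that more compound is needed for the effect, a lower number that less compound is needed), compound 1 gives 4 uM.
Compound 2 `CC(C)(N)CC(=O)N[C@@H]1CCc2ccccc2N(Cc2ccc(-c3ccccc3S(N)(=O)=O)cc2)C1=O` — in this assay compound 2 gives 3 uM.

Compound 2 holds the lowest of the two numbers, but compound 1 lies within the scatter of it: the step from compound 1 to compound 2 reads a 1.3-fold lower number from compound 1 to compound 2 (0.12 log units; within the scatter), so the two compounds cannot be told apart on these numbers.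

Compound 3 `CC(C)(N)CC(=O)N[C@@H]1CCc2ccccc2N(Cc2ccc(-c3ccccc3C#N)cc2)C1=O` carries a different group on the same aromatic carbon, namely (cyano in place of sulfamoyl on an aromatic carbon). Among the compounds with values here, the only measured step, a 1.3-fold lower number from compound 1 to compound 2 (0.12 log units; within the scatter), touched the sulfamoyl group as well, but only its nitrogen substituent, and that step stayed within the scatter. Within the data shown here, no measured step removes the sulfamoyl group entirely or replaces it with a cyano group, so the bearing of the one measured step on compound 3 is indirect. Given the flat outcome of the one step that altered this group, compound 3 is expected to sit near compound 2, with a modest step of a 1.7-fold higher number from compound 2 to compound 3 (0.22 log units; within the scatter) in either direction. The estimate for compound 3 is 5 uM, with a range from 1.5 uM to 15 uM.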

Compound 3, concentration for half-maximal effect: 5 uM
The estimate for compound 3 equals the measured number at the digits printed; the measured number falls inside the stated range.
By their numbers in this assay, from the lowest: compounds 2, 1 and 3 (each within the scatter of the next).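

Compounds 1 and 2 differed only in what sat on the sulfonamide nitrogen, whereas compound 3 replaces the whole sulfamoyl group on this aromatic carbon with a cyano group, so the sulfur, both oxygens and the hydrogen-bond donor all leave and two heavy atoms take the place of four. Even so, this assay does not separate the compounds: the change reads (a 1.7-fold higher number from compound 2 to compound 3 (0.22 log units; within the scatter)) against the sulfamoyl compound and (a 1.3-fold higher number from compound 1 to compound 3 (0.10 log units; within the scatter)) against the tert-butyl compound, and both steps lie within the scatter, so among these three compounds a sulfonyl group at this position is not required for a number in this range. Nothing available explains why the three numbers sit so close together.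

The compounds shown all carry a group containing nitrogen at this position, so it remains open whether a carboxylic acid, a methyl group or a plain hydrogen on the same carbon would also stay within the scatter. A primary amine or a longer chain ending in an amide is equally untested here, so how much room this position allows before the number truly shifts cannot yet be said.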